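The source may hold more compounds than are shown below. What is called first, only, known or untested is meant among the compounds shown, and "the series" means these compounds.

In a functional assay on HeLa cells (Homo sapiens) for antiproliferative activity, read by cell counting, with a stated time of 2 days (a lower number here means a stronger inhibitor, a higher number a weaker inhibitor), compound 3 (`Nc1nc(N2CCCC2)sc1C(=O)c1ccc(Br)cc1`) gives > 200000 nM as its reading, which is a limit of the assay and not a number. Compound 1 (`COc1cccc(C(=O)c2sc(N3CCCC3)nc2N)c1`) gives > 200000 nM as its reading, again a limit. Compound 2 (`Nc1nc(N2CCCC2)sc1C(=O)c1ccc(Cl)cc1`) gives > 200000 nM as its reading, also a limit. All the measured compounds thus share one reading (the limit of > 200000 nM in this assay, at which 3 of the 3 values shown sit) and cannot be ranked against each other. Compound 4 (`Nc1nc(N2CCCC2)sc1C(=O)c1ccccc1`) differs from compound 3 by a single change (hydrogen in place of bromo on an aromatic carbon) with hydrogen in place of bromo on an aromatic carbon, para to a large group. The closest measured change is a step that the two limits leave unreadable from compound 2 to compound 3 and it offers no size to carry over. Since compound 3 rests at > 200000 nM as a limit, no step beyond the scatter can be foreseen, and compound 4 is expected to stay weak in this assay and probably to be reported as a limit again. The estimated step is a number no higher from compound 3 to compound 4 (the limit leaves the size open) in size. For compound 4 the expected value is 200000 nM within an estimated range from 60000 nM to 400000 nM for this measurement.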

Compound 4, half-maximal inhibitory concentration: > 200000 nM
Compound 4: only a limit was reported; the forecaster's own chance of this, stated with the estimate: 80%; the middle value sits exactly at the limit.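

No step can be read between compound 4 and compound 1, compound 2 or compound 3, since all four share one reading: the limit of > 200000 nM in this assay, at which 4 of the 4 values shown sit. In this assay these compounds leave open how strongly any of them acts and whether changing the group on the aromatic ring matters at all.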